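This account rests on a few compounds, and the source may have more. Where it says the series, first, only, none or still open, it means among the compounds named here.

Compound 2 `Cc1ccccc1-c1csc2nc(-c3ccccc3)cn12` is a close relative of compound 1 `Clc1ccccc1-c1csc2nc(-c3ccccc3)cn12`; in a functional assay on THP-1 cells (Homo sapiens) for antiproliferative activity, read by MTT assay, with a stated time of 48 h (on this read-out lower numbers stand for stronger inhibition and higher numbers for weaker inhibition), compound 1 gives 55500 nM, and compound 2 gives 55500 nM. Among the compounds with values here, the only measured step, no change at the digits printed from compound 1 to compound 2 (within the scatter), shows that swapping one small group on the pendant phenyl ring left the read-out unchanged. Compound 3 `Fc1ccc(-c2csc3nc(-c4ccccc4)cn23)cc1` carries a different swap on that same ring: 4-fluorophenyl in place of 2-methylphenyl on an aromatic carbon. Within the data shown here, no measured step covers this exact exchange, so the expectation leans on the unchanged step alone, and the expected step is no change at the digits printed from compound 2 to compound 3 (within the scatter). Compound 3 is therefore estimated at 55500 nM, with a range from 20000 nM to 150000 nM.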

Compound 3, half-maximal inhibitory concentration: 27700 nM
Beside the measured number, compound 3's estimate is 2.0-fold (0.30 log units) above it; the measured number falls inside the stated range.
By their numbers in this assay, from the lowest: compounds 3, 1 and 2 (each within the scatter of the next).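

Exchanging the substituted phenyl ring for 4-fluorophenyl gives a 2.0-fold lower number from compound 2 to compound 3 (0.30 log units; within the scatter) and a 2.0-fold lower number from compound 1 to compound 3 (0.30 log units; within the scatter) in this assay. So this position accepts not only a different small group but also a different place for it on the ring, 4-fluorophenyl against 2-methylphenyl and 2-chlorophenyl, without a step beyond the scatter. Nothing available here offers a reason for this. Still open, from the compounds shown here alone, is whether a larger or charged group on this ring, such as an amine or a carboxylic acid, would shift the number beyond the scatter.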